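Swapping the hydroxyphenyl arm for isopropyl on the core

A few compounds are considered here, and "the series" means these few. Any claim that something is new, unique, unknown or untested is made for them only; others in the source may bear on it.

Measured so far:
compound 1 `CC(C)CC1n2cncc2CN(Cc2ccc(OC(F)(F)F)cc2)S1(=O)=O`: 104 nM
compound 2 `CC(C)CC1n2cncc2CN(C2CC2)S1(=O)=O`: > 1000 nM
compound 3 `C[C@@H](c1ccc(Cl)cc1)N1Cc2cncn2C(C[C@@H](O)c2ccccc2)S1(=O)=O`: 2.4 nM

In an assay on cells for inhibition of cytochrome P450 11B2, mitochondrial (Homo sapiens) (a higher number here means a weaker inhibitor, a lower number a stronger inhibitor), compound 3 gives 2.4 nM, the lowest of the two numbers shown. Compound 1 shares the isobutyl on the core with compound 2 but carries a different group on the sulfonamide nitrogen; in this assay compound 1 gives 104 nM, a number that stands above compound 3 well beyond the scatter. For compound 2 the assay reports only a limit, > 1000 nM, and the limit of > 1000 nM in this assay, at which 1 of the 3 values shown sits, marks that this is a limit of the assay rather than a number.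

Compound 4 `CC(C)CC1n2cncc2CN([C@@H](C)c2ccc(Cl)cc2)S1(=O)=O` is not yet measured. It matches compound 3 except for one change: isopropyl in place of hydroxy(phenyl)methyl on a saturated chain carbon bound to a saturated ring carbon. The same difference, cut one bond further out, reads: 2-hydroxy-2-phenylethyl to isobutyl. Compound 4 thus carries the isobutyl of compounds 1 and 2 while keeping the nitrogen substituent of compound 3.

Among the compounds with values here, no step between measured compounds covers this change alone. The two isobutyl compounds sit well above compound 3, so compound 4 is expected to give a higher number than compound 3, by a step beyond the scatter, a 13-fold higher number from compound 3 to compound 4 (1.10 log units; beyond the scatter). Compound 4 is estimated at 30 nM in this assay, within 8 nM to 150 nM.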

Compound 4, half-maximal inhibitory concentration: 9.4 nM
For compound 4 the middle estimate is 3.2-fold (0.50 log units) above the measured one; low and high end bracket the measured number.
By their numbers in this assay, from the lowest: compound 3; then compound 4; then compound 1. At a limit, above all of these: compound 2.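

In this assay, putting isopropyl in place of hydroxy(phenyl)methyl on a saturated chain carbon bound to a saturated ring carbon gives a 3.9-fold higher number from compound 3 to compound 4 (0.59 log units; beyond the scatter), a modest step, so a low number at this position does not depend on keeping the phenyl ring and the hydroxyl of that arm. The isobutyl group also proves compatible with a low number when the sulfonamide nitrogen keeps the substituent of compound 3: compound 4 gives 9.4 nM, whereas compound 1, with the same isobutyl and a different group on that nitrogen, gives 104 nM. Nothing in the data at hand accounts for the size of the step from the hydroxylated arm to isobutyl.

Which part of the arm accounts for that step remains open, since a plain 2-phenylethyl chain or a 2-hydroxypropyl chain would be needed to separate the phenyl ring from the hydroxyl. Going by these compounds, how a longer alkyl chain, an amine or a carboxylic acid would read at this position in this assay also remains open.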